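This account rests on a few compounds, and the source may have more. Where it says the series, first, only, none or still open, it means among the compounds named here.

Values in a functional assay (blood) for inhibition, with Homo sapiens as the target; a higher number here means a weaker inhibitor, a lower number a stronger inhibitor:
- Compound 1 `CC(C)(C)Sc1c(CC(C)(C)C(=O)O)n(Cc2ccc(Cl)cc2)c2ccc(OCc3ccc4cc(F)ccc4n3)cc12`: 880 nM
- Compound 2 `CC(C)(C)Sc1c(CC(C)(C)C(=O)O)n(Cc2ccc(Cl)cc2)c2ccc(OCc3ccc4cc(F)c(F)cc4n3)cc12`: > 3000 nM
- Compound 3 `CC(C)(C)Sc1c(CC(C)(C)C(=O)O)n(Cc2ccc(Cl)cc2)c2ccc(OCc3cc4ccccc4cn3)cc12`: not yet measured

Compound 2 stands at > 3000 nM, which is a limit and not a number. Among the compounds with values here, the one measured step is an at least 3.4-fold higher number from compound 1 to compound 2 (0.53 log units; beyond the scatter), with fluoro in place of hydrogen on an aromatic carbon. The next change is a group of 10 heavy atoms (9 carbon, 1 nitrogen; one six-membered aromatic ring of carbon only, one six-membered aromatic ring with 1 hetero atom) in place of a group of 12 heavy atoms (9 carbon, 1 nitrogen, 2 fluorine; one six-membered aromatic ring of carbon only, one six-membered aromatic ring with 1 hetero atom), on a saturated chain carbon bound to an oxygen on an aromatic ring, and isoquinolin-3-yl is the group that enters. Within the data shown here, no measured step covers this new ring, so the range stays wide. The number in this assay is expected to fall towards compound 1 at 880 nM, given the rise seen in an at least 3.4-fold higher number from compound 1 to compound 2 (0.53 log units; beyond the scatter). The expected change is an at least 2.5-fold lower number from compound 2 to compound 3 (0.39 log units; beyond the scatter). The estimate for compound 3 is 1200 nM, with an expected range of 350 nM to 3500 nM.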

Compound 3, half-maximal inhibitory concentration: > 3000 nM
Compound 3 gave a limit, no number (the forecaster's own chance of this, stated with the estimate: 20%); middle value at least 2.5-fold (0.39 log units) away from the limit.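

In this assay compound 3 gives > 3000 nM, which is a limit and not a number. Isoquinolin-3-yl in place of 6-fluoroquinolin-2-yl gives an at least 3.4-fold higher number from compound 1 to compound 3 (0.53 log units; beyond the scatter), so at this position a change of ring system, and not only added fluoro, moves the number away from compound 1. The step from compound 2 to compound 3 cannot be read: the limit of > 3000 nM in this assay, at which 2 of the 3 values shown sit.

As far as these compounds go, how far compound 2 and compound 3 lie past their limits stays open. Also open, from the compounds shown here alone, is whether quinolin-2-yl without fluoro, or a single pyridin-2-yl ring, would give a lower number than compound 1.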